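Taking the Hydroxy Off a Weak Phenol Pair

This account rests on a few compounds, and the source may have more. Where it says the series, first, only, none or still open, it means among the compounds named here.

Compound 1 `Oc1ccccc1-c1cncnc1` is a small two-ring molecule carrying a hydroxy on an aromatic carbon. In a functional assay on MCF7 cells (Homo sapiens) for cytotoxicity, read by MTT assay, with a stated time of 2 days (a lower number here means a stronger inhibitor, a higher number a weaker inhibitor), compound 1 gives 61000 nM. For the measured compounds named here, its only neighbour in the data, compound 2 `Oc1ccccc1-c1ncccn1`, gives 41000 nM in this assay; the two numbers lie within the usual scatter, so compound 1 holds the higher of the two numbers without any real separation from compound 2. Compound 3 `c1ccc(-c2cncnc2)cc1` has not yet been tested. It differs from compound 1 by hydrogen in place of hydroxy on an aromatic carbon of a six-membered aromatic ring of carbon only. Going by the values given here, no measured pair shows this change, so the direction is a guess. Since both measured compounds are already weak, the expected step is a 1.4-fold higher number from compound 1 to compound 3 (0.14 log units; within the scatter) in this assay, leaving compound 3 similar or somewhat weaker. Compound 3 is therefore expected to give about 85000 nM, within 30000 nM to 250000 nM.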

Compound 3, half-maximal inhibitory concentration: 7000 nM
The estimate for compound 3 lay 12-fold (1.08 log units) above the measured number; measured number below the stated range.
By their numbers in this assay, from the lowest: compound 3; then compounds 2 and 1 (each within the scatter of the next).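

In this assay, for the compounds shown here, hydrogen in place of hydroxy on an aromatic carbon brings an 8.7-fold lower number from compound 1 to compound 3 (0.94 log units; beyond the scatter) and so takes the series beyond the scatter for the first time. At this position, ortho to a group of 6 heavy atoms, the hydroxy is therefore not needed for the activity seen in this cell assay, and in this one pair the compound without it is the stronger inhibitor. Nothing in the data explains the size or direction of this step.

A single pair cannot show whether the gain comes simply from losing the hydroxy or whether a methoxy group or an amine at the same place would do as well. Going by these compounds, it also remains open whether the same change would bring a similar step on compound 2.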